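Ether substituent exchange: cyclohexyl to 4-fluorobenzyl

The source may hold more compounds than are shown below. What is called first, only, known or untested is meant among the compounds shown, and "the series" means these compounds.

Three compounds of this series have numbers in a functional assay on HEK293 cells for negative allosteric modulation of metabotropic glutamate receptor 5 (Homo sapiens), read by FLIPR and calcium flux; on this read-out higher numbers stand for weaker inhibition and lower numbers for stronger inhibition. Compound 1 `Cc1cccc(NC(=O)c2nn(C)c(-c3ccccc3)c2C)n1`, which carries a phenyl on an aromatic carbon of the shared core, gives 4.4 nM in this assay. Compound 2 `Cc1cccc(NC(=O)c2nn(C)c(-c3cc(F)cc(F)c3)c2C)n1`, with a 3,5-difluorophenyl in that place, gives 5.3 nM, and a 1.2-fold higher number from compound 1 to compound 2 (0.08 log units; within the scatter). Compound 3 `Cc1cccc(NC(=O)c2nn(C)c(OC3CCCCC3)c2C)n1`, with cyclohexyloxy in place of the phenyl, gives 92 nM; this is the highest of the three numbers, with a 21-fold higher number from compound 1 to compound 3 (1.32 log units; beyond the scatter) and a 17-fold higher number from compound 2 to compound 3 (1.24 log units; beyond the scatter).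

Compound 4 `Cc1cccc(NC(=O)c2nn(C)c(OCc3ccc(F)cc3)c2C)n1` is not yet measured. Relative to compound 3 the change is 4-fluorobenzyl in place of cyclohexyl on an oxygen on an aromatic ring. Among the measured compounds shown here, no measured step covers this exact exchange: the two large steps leading to compound 3 swapped a ring bonded directly to the core for an ether, whereas here the oxygen stays and only the group on it changes. Those steps show that an aromatic ring bonded to the core goes with lower numbers; whether an aromatic ring reached through the oxygen recovers any of that is not shown. The expected step in this assay is therefore modest, a 1.7-fold lower number from compound 3 to compound 4 (0.22 log units; within the scatter), toward a somewhat lower number. Compound 4 is estimated at 55 nM, within 18 nM to 180 nM.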

Compound 4, half-maximal inhibitory concentration: 911 nM
Beside the measured number, compound 4's estimate is 17-fold (1.22 log units) below it; measured number outside the range, above it.
By their numbers in this assay, from the lowest: compounds 1 and 2 (each within the scatter of the next); then compound 3; then compound 4.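

In this assay the group carried by the oxygen clearly matters, with a 9.9-fold higher number from compound 3 to compound 4 (1.00 log units; beyond the scatter) beyond the scatter, so this place on the shared core responds to a change made past the ether oxygen and not only to loss of the directly bonded ring. An aromatic ring as such does not go with a low number here: compound 4 carries one through the oxygen and has the highest number of the four at 911 nM in this series, whereas compounds 1 and 2, with the ring bonded directly to the core, have the lowest numbers. Nothing available explains the rise from the cyclohexyl to the 4-fluorobenzyl.

The compounds shown do not separate the contribution of the fluorine from that of the benzyl group, a question that an unsubstituted benzyl on the oxygen would address. They also leave open how a small group such as methyl on the oxygen, or an amine in place of the ether oxygen, would behave at this place.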